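A few compounds are considered here, and "the series" means these few. Any claim that something is new, unique, unknown or untested is made for them only; others in the source may bear on it.

Measured so far in a functional assay on MCF7 cells (Homo sapiens) for antiproliferative activity, read by CellTiter-Glo, with a stated time of 5 days; on this read-out higher numbers stand for weaker inhibition and lower numbers for stronger inhibition:

- Compound 1 `CC/C(=C(/c1ccc(/C=C/C(=O)O)cc1)c1ccc2[nH]ncc2c1)c1ccccc1` gives 7.2 nM
- Compound 2 `CC/C(=C(/c1ccc(/C=C/C(=O)O)cc1)c1ccc2ncsc2c1)c1ccccc1` gives only a limit, > 500 nM
- Compound 3 `O=C(O)/C=C/c1ccc(/C(=C(\c2ccc(F)cc2Cl)C2CCC2)c2ccc3scnc3c2)cc1` gives 3 nM

Compound 3 holds the lowest of the two exact numbers, and its gap to compound 1 lies beyond the scatter. Compound 4 `N#Cc1cc(Cl)ccc1/C(=C(\c1ccc(/C=C/C(=O)O)cc1)c1ccc2scnc2c1)C1CCC1` differs from compound 3 in one place, on a double-bonded chain carbon bound to a double-bonded chain carbon and a saturated ring carbon: 4-chloro-2-cyanophenyl in place of 2-chloro-4-fluorophenyl on a double-bonded chain carbon bound to a double-bonded chain carbon and a saturated ring carbon. For the measured compounds named here, the only measured step, an at least 69-fold higher number from compound 1 to compound 2 (1.84 log units; beyond the scatter), exchanges other groups at another place. It shows that one change can matter greatly in this assay, but it gives no size for this one. Going by the values given here, with no measured step at this place, only a small move toward weaker inhibition is expected, a 1.7-fold higher number from compound 3 to compound 4 (0.22 log units; within the scatter). Compound 4 is estimated at 5 nM, with an expected range from 1.5 nM to 25 nM.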

Compound 4, half-maximal inhibitory concentration: 0.9 nM
Compound 4: middle estimate off by 5.6-fold (0.74 log units), on the high side; the whole stated range lies above it.
By their numbers in this assay, from the lowest: compound 4; then compound 3; then compound 1. At a limit, above all of these: compound 2.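

In this assay, the ring on this double-bonded chain carbon still has room to tune activity, even in a compound whose number is already low: 4-chloro-2-cyanophenyl in place of 2-chloro-4-fluorophenyl gives a 3.3-fold lower number from compound 3 to compound 4 (0.52 log units; beyond the scatter). For the compounds shown here, this is the first measured step at this place, and it runs toward stronger inhibition. Nothing shown here explains the drop.

This swap changes several features at once, so the nitrile and the rearranged halogens cannot be separated. From the compounds shown here alone, whether a methoxy or an amide in place of the nitrile would hold this activity remains open.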